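The source may report more compounds than this note shows. Statements on the series, on what has been measured and on what is new or still open speak of the compounds shown alone.

Measured compounds in the series:
- compound 1 `CC[C@H](NC(=O)COc1ccc2[nH]c(=O)c(-c3nccs3)c(CCc3ccccc3)c2c1)c1ccccc1`; in a functional assay on CHO cells for antagonist activity at adenosine receptor A2b (Homo sapiens), read by cAMP accumulation, with stated times of 15 min and 1 h (a higher number here means a weaker inhibitor, a lower number a stronger inhibitor), compound 1 gives 7.4 nM.
- compound 2 `CS(=O)(=O)c1c(CCc2ccccc2)c2cc(OCC(=O)NCC3CC3)ccc2[nH]c1=O`; in this assay compound 2 gives > 5000 nM, which is a limit and not a number.

Compound 2 therefore stands at the limit of > 5000 nM in this assay, at which 1 of the 2 values shown sits, and nothing more than that is known of it. Among the compounds with values here, compound 1 and compound 2 differ in more than one place, so their two values show only that compound 1 is resolved as an inhibitor while compound 2 is not.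

Compound 3 `CS(=O)(=O)c1c(CCc2ccccc2)c2cc(OCC(=O)Nc3ccccc3)ccc2[nH]c1=O` follows from compound 2 by phenyl in place of cyclopropylmethyl on an amide-type nitrogen whose other neighbour is a carbonyl carbon. Within the data shown here, no measured step of this kind exists; compound 1 also carries an aromatic substituent near the amide nitrogen, but it differs from compound 2 in a second place as well, so its value cannot be read as the size of this change. The expected step in this assay from compound 2 to compound 3 is a step that the limit leaves unreadable from compound 2 to compound 3, that is, nothing beyond the scatter, and a limit again seems the most probable read-out. Compound 3 is estimated at 6000 nM, in the range 1500 nM to 30000 nM.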

Compound 3, inhibition constant: 1680 nM
The estimate for compound 3 lay 3.6-fold (0.55 log units) above the measured number; the range from low to high includes it.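

In this assay compound 3 gives a resolved value of 1680 nM, so with the shared core held constant, the group on the amide-type nitrogen is a place where the read-out can be moved into measurable range. Phenyl in place of cyclopropylmethyl on this nitrogen gives an at least 2.9-fold lower number from compound 2 to compound 3 (0.47 log units; beyond the scatter), the first single-place step in the series, and it shows that this change lowers the number by more than the usual scatter. Compound 2 carries a limit and not a number, so this step has a floor but no known upper end: the limit of > 5000 nM in this assay, at which 1 of the 3 values shown sits.

From the compounds shown here alone, it remains open whether the step follows the aromatic character of phenyl or the change from a three-membered to a six-membered ring, and cyclohexyl or benzyl on the same nitrogen would separate these two readings. Compound 1, at 7.4 nM, differs from compound 3 in more than one place, so its value cannot be assigned to any single change.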